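Adding a Hydroxy Group to a Hydrazone Analogue

The source may hold more compounds than are shown below. What is called first, only, known or untested is meant among the compounds shown, and "the series" means these compounds.

Measured so far:
Compound 1: `O=[N+]([O-])c1cccc(CSc2nnc(-c3ccncc3)n2-c2ccccc2)c1` — 19800 nM
Compound 2: `O=C(CSc1nnc(-c2ccncc2)n1-c1ccccc1)N/N=C/c1ccccc1` — 14700 nM

Both compounds were tested in a functional assay on HCT-116 cells (Homo sapiens) for inhibition, read by MTT assay, with a stated time of 48 h; on this read-out lower numbers stand for stronger inhibition and higher numbers for weaker inhibition. Compound 1 gives 19800 nM, and compound 2 gives 14700 nM. Compound 2 has the lower of the two numbers, but the gap to compound 1 sits within the usual scatter of this kind of measurement, so the two cannot be told apart on potency.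

Compound 3, `O=C(CSc1nnc(-c2ccncc2)n1-c1ccccc1)N/N=C/c1ccc(O)cc1`, has not yet been measured in this assay. It differs from compound 2 in one place: hydroxy in place of hydrogen on an aromatic carbon, in words a hydroxy in place of hydrogen on an aromatic carbon. For the measured compounds named here, no measured pair in this set shows what such a change does, so the expectation rests on compound 2 alone.

The number for compound 3 in this assay is expected to stay close to that of compound 2, with at most a modest shift toward stronger inhibition, a step of a 1.5-fold lower number from compound 2 to compound 3 (0.17 log units; within the scatter). The estimate for compound 3 is 10000 nM, within a range of 4000 nM to 30000 nM.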

Compound 3, half-maximal inhibitory concentration: > 50000 nM
Compound 3: no number, only a limit; the forecaster's own chance of this, stated with the estimate: 10%; at least 5.0-fold (0.69 log units) between middle value and limit.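

Putting a hydroxy on the aromatic ring, para to a large group, turns phenyl into 4-hydroxyphenyl and gives an at least 3.4-fold higher number from compound 2 to compound 3 (0.53 log units; beyond the scatter) in this assay. For the compounds shown here, this is the first comparison here that differs in one place, and it shows that this position is not indifferent to a small change: a single added hydroxy moves the result toward weaker inhibition, beyond the scatter. Compound 3 has only a limit of the assay, > 50000 nM, and not a number, so the full size of the step stays unread: the limit of > 50000 nM in this assay, at which 1 of the 3 values shown sits.

The compounds shown leave open whether this loss is specific to the hydroxy or would also follow another group at the same place, such as a methoxy or an amine. They also leave open whether the same change would act alike on the aromatic rings of compound 1.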